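The compounds below may be only part of what the source reports. "The series", "measured", "known", "first", "only" and "open" are said of these compounds alone.

Measured so far:
compound 1 `CN1CCN(c2ccc(C3=NN(S(=O)(=O)c4ccc(F)cc4)C(c4ccc(N(C)C)cc4)C3)cc2)CC1`: 92.3%
compound 2 `CN(C)c1ccc(C2CC(c3ccc(-n4cncn4)cc3)=NN2C(=O)c2cc(Cl)cc(Cl)c2)cc1`: 5.3%

In a functional assay on HCC1806 cells (Homo sapiens) for inhibition, read by sulforhodamine B assay, tested at 10 uM (a higher number here means more inhibition at the concentration tested (going by the name of the read-out), a lower number less inhibition), compound 2 stands lowest of the two numbers; its nearest neighbour is compound 1, which lies higher by a gap beyond the scatter. Among the measured compounds shown here, the two differ in more than one place, so no single step between them is drawn. The next compound, compound 3 `CN(C)c1ccc(C2CC(c3ccc(-n4cncn4)cc3)=NN2S(=O)(=O)c2ccc(F)cc2)cc1`, is compound 2 with one change: (4-fluorophenyl)sulfonyl in place of (3,5-dichlorophenyl)carbonyl on an amine nitrogen in a ring. For the measured compounds named here, the group that enters is the one compound 1 carries on its ring nitrogen, and compound 1 gives 92.3% in this assay, so a rise from compound 2 is expected, large and beyond the scatter, though the other aryl group on the ring differs between compound 1 and compound 3 and no step for that difference is known. The expected step is a number 64.7 percentage points higher from compound 2 to compound 3 (beyond the scatter). Compound 3 is estimated at 70%, with a range from 35% to 95%.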

Compound 3, a percentage reported as inhibition, at one concentration (the size of the read-out at that concentration, not a potency): 24.1%
Compound 3: middle estimate off by 45.9 percentage points, on the high side, outside the stated range (below it).
By their numbers in this assay, from the lowest: compound 2; then compound 3; then compound 1.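

In this assay the change of (3,5-dichlorophenyl)carbonyl to (4-fluorophenyl)sulfonyl on the amine nitrogen in the ring gives only a number 18.8 percentage points higher from compound 2 to compound 3 (beyond the scatter) and leaves the value low. The large change lies on the aromatic carbon, where 1H-1,2,4-triazol-1-yl in place of 4-methylpiperazin-1-yl gives a number 68.2 percentage points lower from compound 1 to compound 3 (beyond the scatter) in the same assay, so the (4-fluorophenyl)sulfonyl group alone does not bring the high value of the 4-methylpiperazin-1-yl compound. Nothing shown accounts for either step.

On these data alone, whether the carbonyl-to-sulfonyl step keeps its size when 4-methylpiperazin-1-yl sits on the aromatic carbon stays open. Also open, as far as these compounds go, is whether morpholin-4-yl or an unsubstituted piperazin-1-yl at that carbon would hold the value or lose it, as 1H-1,2,4-triazol-1-yl does.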